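Permeability of quinoline analogues: an aryl for cyclohexyl swap

The compounds below may be only part of what the source reports. "The series", "measured", "known", "first", "only" and "open" are said of these compounds alone.

Measured compounds:
compound 1, `COc1cccc(CNCCCNc2ccnc3cc(Oc4ccccc4)ccc23)c1O`, 317 10^-6 cm/s
compound 2, `COc1ccc(-c2ccc3c(NCCCNCc4cccc(OC)c4O)ccnc3c2)cc1`, 237 10^-6 cm/s
compound 3, `COc1cccc(CNCCCNc2ccnc3cc(C4CCCCC4)ccc23)c1O`, 23 10^-6 cm/s

In an ADME assay for permeability, using PAMPA, with a stated time of 30 min, at pH 7.4 (a higher number here means that the compound crosses the layer faster, a lower number that the compound crosses the layer more slowly), compound 3 gives 23 10^-6 cm/s, the lowest of the three numbers; the nearest is compound 2, and the step of a 10-fold lower number from compound 2 to compound 3 (1.01 log units; beyond the scatter) lies beyond the scatter, while the furthest is compound 1, with a 14-fold lower number from compound 1 to compound 3 (1.14 log units; beyond the scatter). Compound 4, `COc1cccc(CNCCCNc2ccnc3cc(-c4ccc(C(C)(C)C)cc4)ccc23)c1O`, has not yet been measured. It differs from compound 3 by 4-(tert-butyl)phenyl in place of cyclohexyl on an aromatic carbon.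

Going by the values given here, two measured steps bear on this change. Replacing phenoxy by cyclohexyl gave a 14-fold lower number from compound 1 to compound 3 (1.14 log units; beyond the scatter), and replacing 4-methoxyphenyl by cyclohexyl gave a 10-fold lower number from compound 2 to compound 3 (1.01 log units; beyond the scatter); both are large and both point the same way. Among the compounds with values here, the step from compound 3 to compound 4 runs in the opposite direction, restoring an aromatic ring at this position, so a rise in this assay well beyond the scatter is expected, though no measured pair shows exactly a 4-(tert-butyl)phenyl group, so the size is uncertain. For compound 4 the expected step is a 6.5-fold higher number from compound 3 to compound 4 (0.81 log units; beyond the scatter). The estimate for compound 4 in this assay is 150 10^-6 cm/s, with a range from 45 10^-6 cm/s to 400 10^-6 cm/s.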

Compound 4, apparent permeability: 237 10^-6 cm/s
Compound 4: middle estimate off by 1.6-fold (0.20 log units), on the low side; measured number inside the range.
By their numbers in this assay, from the lowest: compound 3; then compounds 2, 4 and 1 (each within the scatter of the next).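

In this assay, 4-(tert-butyl)phenyl in place of cyclohexyl on this aromatic carbon gives a 10-fold higher number from compound 3 to compound 4 (1.01 log units; beyond the scatter), which shows that a large rise is also reached with an aryl group carrying no hydrogen-bond acceptor and made of carbon alone. Tert-butyl in place of methoxy gives no change at the digits printed from compound 2 to compound 4 (within the scatter), and 4-(tert-butyl)phenyl in place of phenoxy gives a 1.3-fold lower number from compound 1 to compound 4 (0.13 log units; within the scatter), so compounds 1, 2 and 4 sit together within the scatter, and compound 3, the only one of the four with a non-aromatic ring at this position, stands alone with no compound going against that split. Nothing among the data given explains why the non-aromatic ring goes with the low number.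

The compounds shown leave open whether the low number belongs to non-aromatic rings in general or to cyclohexyl alone, a question that a cyclopentyl group or a piperidine ring at this position would address. As far as these compounds go, it also remains open whether the aryl compounds would stay level if the aromatic ring carried an amine or a carboxylic acid in place of methoxy or tert-butyl.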